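The source may hold more compounds than are shown below. What is called first, only, known or untested is meant among the compounds shown, and "the series" means these compounds.

In a functional assay on HCC1806 cells (Homo sapiens) for inhibition, read by sulforhodamine B assay, tested at 10 uM (on this read-out higher numbers stand for more inhibition at the one concentration tested (going by the name of the read-out) and lower numbers for less inhibition), compound 1 `COC(=O)CC(=O)N1N=C(c2ccc(N3CCN(C)CC3)cc2)CC1c1ccc(N(C)C)cc1` gives -8.3%.
In this assay, compound 2 `CN1CCN(c2ccc(C3=NN(C(=O)/C=C/c4ccccc4)C(c4ccc(N(C)C)cc4)C3)cc2)CC1` gives 71%.
In this assay, compound 3 `COC(=O)CC(=O)N1N=C(c2ccc(-n3cncn3)cc2)CC1c1ccc(N(C)C)cc1` gives -7.8%.

Among these three numbers compound 3 stands second highest. Its nearest neighbour is compound 1: the step of a number 0.5 percentage points higher from compound 1 to compound 3 (within the scatter) lies within the usual scatter, so the two are not told apart. Compound 2 stands far above both, the only one of the three showing clear inhibition at the concentration tested.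

Compound 4 `CN(C)c1ccc(C2CC(c3ccc(-n4cncn4)cc3)=NN2C(=O)/C=C/c2ccccc2)cc1` is the next compound. It differs from compound 3 in a single place: 2-phenylethenyl in place of (methoxycarbonyl)methyl on a carbonyl carbon. This is the same exchange that separates compound 1 from compound 2, and there it was measured directly: a number 79.3 percentage points higher from compound 1 to compound 2 (beyond the scatter), a large step beyond the scatter. Among the compounds with values here, since the step from compound 1 to compound 3 shows that the other part of the structure hardly matters on this read-out, the measured pair compound 1 to compound 2 is the one that bears on compound 4.

A rise of about the same size is therefore expected for compound 4, namely a number 77.8 percentage points higher from compound 3 to compound 4 (beyond the scatter). Compound 4 is expected to give 70%, in a range from 45% to 90%.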

Compound 4, a percentage reported as inhibition, at one concentration (the size of the read-out at that concentration, not a potency): -3.7%
Beside the measured number, compound 4's estimate is 73.7 percentage points above it, and the stated range ends above it.
By their numbers in this assay, from the lowest: compounds 1, 3 and 4 (each within the scatter of the next); then compound 2.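

On the core carrying 1H-1,2,4-triazol-1-yl, placing 2-phenylethenyl on the carbonyl carbon in place of (methoxycarbonyl)methyl gives only a number 4.1 percentage points higher from compound 3 to compound 4 (within the scatter), so in this assay this change does not carry the same outcome from one core to another: the same change on two cores in this assay, a number 79.3 percentage points higher (beyond the scatter) from compound 1 to compound 2 and a number 4.1 percentage points higher (within the scatter) from compound 3 to compound 4, 75.2 percentage points apart, beyond the scatter of two such steps

The exchange on the aromatic carbon shows the same dependence, since replacing 4-methylpiperazin-1-yl with 1H-1,2,4-triazol-1-yl gives a number 74.7 percentage points lower from compound 2 to compound 4 (beyond the scatter) when 2-phenylethenyl is present, a clear contrast with its effect when (methoxycarbonyl)methyl is present: the same change on two cores in this assay, a number 0.5 percentage points higher (within the scatter) from compound 1 to compound 3 and a number 74.7 percentage points lower (beyond the scatter) from compound 2 to compound 4, 75.2 percentage points apart, beyond the scatter of two such steps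

The two places therefore cannot be read separately here, and among these four compounds, clear inhibition appears only in compound 2, the one combining 2-phenylethenyl with 4-methylpiperazin-1-yl, while compound 1 and compound 4 each carry just one of these groups and fall with compound 3.

The compounds shown leave open whether the pairing with 2-phenylethenyl requires 4-methylpiperazin-1-yl itself, or whether a morpholin-4-yl ring or a piperazin-1-yl ring without the methyl would serve as well. They also leave open whether a 3-phenylpropanoyl group, with a saturated chain in place of the double bond, would keep the inhibition seen with compound 2.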